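A few compounds are considered here, and "the series" means these few. Any claim that something is new, unique, unknown or untested is made for them only; others in the source may bear on it.

Working notes on the series. Compound 2 `CN(C)c1ccc(/C=C(/SCc2ccc(F)cc2)C(=O)c2ccc(Br)cc2)cc1` is the reference for the first core; in a functional assay on DU-145 cells (Homo sapiens) for inhibition, read by trypan blue exclusion, with a stated time of 96 h (on this read-out lower numbers stand for stronger inhibition of growth and higher numbers for weaker inhibition of growth), compound 2 gives 50000 nM. Compound 1 `O=C(/C(=C\c1c[nH]c2ccc(Cl)cc12)SCc1ccc(F)cc1)c1ccc(Br)cc1` differs from compound 2 by 5-chloro-1H-indol-3-yl in place of 4-(dimethylamino)phenyl on a double-bonded chain carbon bound to a double-bonded chain carbon; in this assay compound 1 gives 1000 nM, and the step is a 50-fold lower number from compound 2 to compound 1 (1.70 log units; beyond the scatter). Compound 3 `Cc1ccc(S(=O)(=O)/C(=C/c2ccc(N(C)C)cc2)C(=O)c2ccc(Br)cc2)cc1` carries the second core, which differs from the first by (4-methylphenyl)sulfonyl in place of (4-fluorobenzyl)sulfanyl on a double-bonded chain carbon bound to a carbonyl carbon and a double-bonded chain carbon; in this assay compound 3 gives 50000 nM, and the step is no change at the digits printed from compound 2 to compound 3 (within the scatter). Compound 4 `Cc1ccc(S(=O)(=O)/C(=C/c2c[nH]c3ccc(Cl)cc23)C(=O)c2ccc(Br)cc2)cc1` is not yet measured; it differs from compound 3 by 5-chloro-1H-indol-3-yl in place of 4-(dimethylamino)phenyl on a double-bonded chain carbon bound to a double-bonded chain carbon. This is the same change as that from compound 2 to compound 1, and it occurs twice among the four compounds; where measured, it made the step of a 50-fold lower number from compound 2 to compound 1 (1.70 log units; beyond the scatter). The expected step of a 25-fold lower number from compound 3 to compound 4 (1.40 log units; beyond the scatter) is taken somewhat smaller than that measured one, as a single precedent on a different core is all that supports it, while compound 2 and compound 3 sit within the scatter of each other, compound 3 giving 50000 nM. Compound 4 is accordingly estimated at 2000 nM in this assay.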

Compound 4, concentration for 50% growth inhibition: 10000 nM
Compound 4: the middle estimate sits 5.0-fold (0.70 log units) below what was measured, within the range that was stated.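

In this assay, 5-chloro-1H-indol-3-yl in place of 4-(dimethylamino)phenyl lowers the number on both cores, but the size of the step does not carry over, the step on the second core being a 5.0-fold lower number from compound 3 to compound 4 (0.70 log units; beyond the scatter): the same change on two cores in this assay, a 50-fold lower number (1.70 log units; beyond the scatter) from compound 2 to compound 1 and a 5.0-fold lower number (0.70 log units; beyond the scatter) from compound 3 to compound 4, 10-fold (1.00 log units) apart, beyond the scatter of two such steps. Within the data shown here, the change of core itself depends on the group present, giving a 10-fold higher number from compound 1 to compound 4 (1.00 log units; beyond the scatter) with 5-chloro-1H-indol-3-yl, whereas the pair with 4-(dimethylamino)phenyl shows no such step: the same change on two cores in this assay, no change at the digits printed (within the scatter) from compound 2 to compound 3 and a 10-fold higher number (1.00 log units; beyond the scatter) from compound 1 to compound 4, 10-fold (1.00 log units) apart, beyond the scatter of two such steps. The direction of the change therefore held on both cores, but its size did not, and two cores give no rule for a third and no explanation of the gap.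

The compounds shown leave open which part of 5-chloro-1H-indol-3-yl carries the step, as the chlorine and the five-membered ring enter together. Also open, from the compounds shown here alone, is how the two cores would compare with other groups on the double-bonded chain carbon, such as an indole with a methoxy group in place of the chlorine.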